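Extending the nitrate chain by one carbon

The source may hold more compounds than are shown below. What is called first, only, known or untested is meant among the compounds shown, and "the series" means these compounds.

- compound 1 `Cc1c(CCOCCO[N+](=O)[O-])cc(-c2ccc(S(C)(=O)=O)cc2)n1-c1ccccc1` reads 6030 nM as a measured number
- compound 2 `Cc1c(CCOCCO[N+](=O)[O-])cc(-c2ccc(S(C)(=O)=O)cc2)n1-c1ccc(F)c(F)c1` reads >= 10000 nM as a limit of the assay, not a number

For the measured compounds named here, in a functional assay on aorta (Rattus norvegicus, strain Wistar) (a higher number here means a weaker inhibitor, a lower number a stronger inhibitor), compound 1 gives 6030 nM as the only true number so far, which leaves nothing measured to rank it against.

Compound 3 `Cc1c(CCOCCCO[N+](=O)[O-])cc(-c2ccc(S(C)(=O)=O)cc2)n1-c1ccccc1` has not yet been measured. It differs from compound 1 by (nitrooxy)methyl in place of nitrooxy on a saturated chain carbon, two bonds along the chain from an oxygen on a saturated carbon with (nitrooxy)methyl in place of nitrooxy on a saturated chain carbon, two bonds along the chain from an oxygen on a saturated carbon.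

Going by the values given here, the one measured step of an at least 1.6-fold higher number from compound 1 to compound 2 (0.21 log units; that floor lies within the scatter) has its floor within the scatter. It concerns a group on an aromatic nitrogen, not this chain, so it gives no size or direction here. No change beyond the scatter is therefore expected in this assay for this edit. The expected step is a 1.0-fold lower number from compound 1 to compound 3 (0.00 log units; within the scatter) on this estimate. For compound 3 the estimated value is 6000 nM with 2500 nM to 10000 nM as its expected range.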

Compound 3, half-maximal inhibitory concentration: >= 10000 nM
Compound 3: no number, only a limit; the forecaster's own chance of this, stated with the estimate: 20%; middle value at least 1.6-fold (0.22 log units) away from the limit.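

For the compounds shown here, this is the first result that bears on the chain itself, as the earlier step changed only the group on the aromatic nitrogen. Going from 2-(nitrooxy)ethoxy to 3-(nitrooxy)propoxy gives an at least 1.6-fold higher number from compound 1 to compound 3 (0.21 log units; that floor lies within the scatter), so in this assay the longer chain shows no gain in strength, though the step cannot be called a real loss either. The size of this step cannot be read from a single floor, and such floors are common in this small set: the limit of >= 10000 nM in this assay, at which 2 of the 3 values shown sit.

On these data alone, how far the true value of compound 3 lies from that of compound 1 stays open. Also open, as far as these compounds go, is whether a still longer chain, or an amine in place of the nitrooxy group, would give a true number in this assay.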